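The compounds below may be only part of what the source reports. "The series", "measured", "known", "first", "only" and "open" are said of these compounds alone.

Compound 1 `Cc1c(N(C)C)nc(CCCCCCCCCCO)c(O)c1C` carries a saturated chain that ends in a hydroxy on the shared core. In a functional assay on cells (Lymphocyte, Homo sapiens) for inhibition, read by flow cytometry, using a membrane potential dye, with a stated time of 16 h, tested at 500 nM (a higher number here means a stronger effect of the compound at the concentration tested, a lower number a weaker effect), compound 1 gives 50%. Compound 2 `CCCCCCCCCCCCCCCCc1c(C)c(N(C)C)nc(C)c1O` carries a saturated chain on the same core with no hydroxy at its end, and in this assay compound 2 gives 91%. Of the two numbers in hand, compound 1 stands lowest; its nearest neighbour, compound 2, lies above it by a gap beyond the scatter.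

Compound 3 `CCCCCCCCCCCCCCCCCCCc1nc(N(C)C)c(C)c(C)c1O` has not yet been measured in this assay. Against compound 1 the difference is nonyl in place of hydroxy on a saturated chain carbon, ten or more bonds along the chain from an aromatic carbon. The chain of compound 3 is thereby saturated to its end, as in compound 2.

Going by the values given here, no step between measured compounds is in hand, so the size of the change must be judged from the two values alone. Compound 2 gives 91% with a chain bearing no hydroxy, so an upward step beyond the scatter is expected for the same kind of chain end. The expected step is a number 35 percentage points higher from compound 1 to compound 3 (beyond the scatter), upward and beyond the scatter. Compound 3 is expected to give 85% in this assay, with a range from 65% to 98%.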

Compound 3, a percentage reported as activity, at one concentration (the size of the read-out at that concentration, not a potency): 65%
Estimate against measurement, compound 3: 20 percentage points above; the measured number falls inside the stated range.
By their numbers in this assay, from the lowest: compound 1; then compound 3; then compound 2.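

On a saturated chain carbon, nonyl in place of hydroxy gives in this assay a single-place step for this series: a number 15 percentage points higher from compound 1 to compound 3 (beyond the scatter). The step is modest but beyond the scatter, so at this position the end hydroxy is not needed for the effect at the tested concentration, and the longer, fully saturated chain is accepted in its place. No measurement given here bears on why the read-out moves, so the step stands without an explanation.

The change removes the hydroxy and lengthens the chain in one move, so the two contributions remain unseparated; a plain decyl chain on the shared core, or a decyl chain ending in an amine or a carboxylic acid, would begin to pull them apart. Since each read-out is taken at one concentration, the values also leave open how far potency differs along the series, and whether a still longer chain at this position would continue the same direction.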